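Solubility of two indole amides at the assay limit

This account rests on a few compounds, and the source may have more. Where it says the series, first, only, none or still open, it means among the compounds named here.

Compound 2 `CCC(CC)NC(=O)c1cc2c(C)cc(C)cc2[nH]1` has been measured in a physicochemical assay for solubility, measured as thermodynamic solubility, with a stated time of 24 h, at pH 6.8; on this read-out higher numbers stand for higher solubility and lower numbers for lower solubility. In this assay compound 2 gives < 4000 nM, which is a limit of the assay rather than a number. Compound 1 `Cc1cc(C)c2cc(C(=O)NC3CCCCC3)[nH]c2c1` likewise gives < 4000 nM in this assay, again a limit. The step that the two limits leave unreadable from compound 1 to compound 2 is therefore not readable. Compound 3 `Cc1cc(C)c2cc(C(=O)N[C@@H]3CCCC[C@@H]3C)[nH]c2c1` differs from compound 2 by 2-methylcyclohexyl in place of pentan-3-yl on an amide-type nitrogen. Among the compounds with values here, no measured step speaks to this change; the only evidence is the limit of < 4000 nM in this assay, at which 2 of the 2 values shown sit. Compound 3 is expected to stay near that limit, with an estimated step that the limit leaves unreadable from compound 2 to compound 3. The estimate for compound 3 in this assay is 1500 nM, between 300 nM and 4000 nM.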

Compound 3, solubility: < 4000 nM
Compound 3 was reported as a limit; the forecaster's own chance of this, stated with the estimate: 80%; the middle value lies beyond the limit too.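

No step can be read among compound 1, compound 2 and compound 3 in this assay, since all three give only a limit: the limit of < 4000 nM in this assay, at which 3 of the 3 values shown sit. Going by these compounds, how far each compound's true solubility lies under that limit remains open.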